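This account rests on a few compounds, and the source may have more. Where it says the series, first, only, none or still open, it means among the compounds named here.

Measured compounds:
compound 1 `CCCc1nc(-c2ccccc2)c(CNCCN2CCN(c3ccccc3Cl)CC2)o1`, 60.1%
compound 2 `CCCc1nc(-c2ccccc2)c(CNCCCN2CCN(c3ccc(OC)cc3)CC2)o1`, 42.1%
compound 3 `CCCc1nc(-c2ccccc2)c(CNCCN2CCN(c3ccc(C(F)(F)F)cc3)CC2)o1`, 58.7%

In an assay on HEK293 cells for inhibition of Voltage-dependent T-type calcium channel subunit alpha-1G (Homo sapiens), read by fluorescence, tested at 10 uM (on this read-out lower numbers stand for less inhibition and higher numbers for more inhibition at the one concentration tested (going by the name of the read-out)), compound 2 stands lowest of the three measured numbers, beyond the scatter below both compound 3 and compound 1. Compound 4 `CCCc1nc(-c2ccccc2)c(CNCCCN2CCN(c3cccc(C)c3)CC2)o1` is not yet measured; its change from compound 2 is 3-methylphenyl in place of 4-methoxyphenyl on an amine nitrogen in a ring.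

Within the data shown here, the only measured step that bears on a swap of the aryl group on the ring nitrogen is a number 1.4 percentage points lower from compound 1 to compound 3 (within the scatter), which stayed within the scatter. Among the measured compounds shown here, no step exchanges a methoxy-bearing phenyl for a methyl-bearing phenyl, so the expectation rests on that one step alone. A step of a number 2.9 percentage points higher from compound 2 to compound 4 (within the scatter) in this assay is therefore expected, that is, none beyond the scatter.

Compound 4 is estimated at 45% in this assay, with a range from 30% to 62%.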

Compound 4, a percentage reported as inhibition, at one concentration (the size of the read-out at that concentration, not a potency): 47.8%
The estimate for compound 4 lay 2.8 percentage points below the measured number; measured number inside the range.
By their numbers in this assay, from the lowest: compounds 2 and 4 (each within the scatter of the next); then compounds 3 and 1 (each within the scatter of the next).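

In this assay, placing 3-methylphenyl where 4-methoxyphenyl stood gives a number 5.7 percentage points higher from compound 2 to compound 4 (within the scatter). This is a second aryl exchange on the ring nitrogen that stays within the scatter, now in the pair carrying the other chain, and the entering group has no hydrogen-bond acceptor where the leaving group has one. No available data bear on why this exchange stays within the scatter. Compounds 1 and 3 each differ from compounds 2 and 4 in more than one place, so the effect of the chain cannot be read. On these data alone, whether an aryl group carrying a carboxylic acid or an amine would fit the same picture remains open.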